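Sulfanyl swap on the shared core: compound 3 to compound 4

A few compounds are considered here, and "the series" means these few. Any claim that something is new, unique, unknown or untested is made for them only; others in the source may bear on it.

Values in an ADME assay on CCRF-HSB-2 cells (Homo sapiens) for cytotoxicity, with a stated time of 7 days (on this read-out higher numbers stand for lower toxicity in this test and lower numbers for higher toxicity in this test), so far:
- compound 1 `COCCOc1nc(N)nc2c1ncn2/C=C1/CC1(CO)CO` gives > 20000 nM as a limit
- compound 2 `CCCSc1nc(N)nc2c1ncn2/C=C1/CC1(CO)CO` gives 98000 nM as a number
- compound 3 `Nc1nc(NC2CCCC2)c2ncn(/C=C3/CC3(CO)CO)c2n1` gives > 20000 nM as a limit

Compound 3 has no number, only the limit > 20000 nM in this read-out. The change to compound 4 `CSc1nc(N)nc2c1ncn2/C=C1/CC1(CO)CO` is methylsulfanyl in place of cyclopentylamino on an aromatic carbon and it puts methylsulfanyl in place of cyclopentylamino on an aromatic carbon. The closest measured change is a step that the limit leaves unreadable from compound 2 to compound 3 and no size can be taken from it. The same holds for a step that the limit leaves unreadable from compound 1 to compound 2 in the series. Going by the values given here, compound 2 carries the only other sulfanyl group, and compound 2 at 98000 nM is the sole numeric anchor. The expected change is a step that the limit leaves unreadable from compound 3 to compound 4 and its direction stays uncertain against a limit. For compound 4 the estimated value is 60000 nM with an expected range from 20000 nM to 150000 nM in this assay and a limit reading is also possible.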

Compound 4, half-maximal cytotoxic concentration: > 100000 nM
Compound 4: no number, only a limit; the forecaster's own chance of this, stated with the estimate: 45%; middle value at least 1.6-fold (0.22 log units) away from the limit.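

Compound 4 gives only a limit in this assay: the limit of > 100000 nM in this assay, at which 1 of the 4 values shown sits. Shortening propylsulfanyl to methylsulfanyl gives an at least 1.0-fold higher number from compound 2 to compound 4 (0.00 log units; that floor lies within the scatter), so the sulfanyl pair offers no sign that the shorter chain brings higher toxicity in this test. The steps from compound 1 and compound 3 to compound 4 cannot be read.

On these data alone, how far the true value of compound 4 lies from that of compound 2 remains open. Also open, as far as these compounds go, is whether a longer chain such as pentylsulfanyl, or a primary amine, on this aromatic carbon would give a lower number.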